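Extending the sulfanyl chain: compound 3 to compound 4

The source may report more compounds than this note shows. Statements on the series, on what has been measured and on what is new or still open speak of the compounds shown alone.

Measured in a functional assay on BGC-823 cells (Homo sapiens) for antiproliferative activity, read by MTT assay; a lower number here means a stronger inhibitor, a higher number a weaker inhibitor:
- compound 1 `C=CCSc1ncnc2ccccc12`: 78100 nM
- compound 2 `COc1cc(-c2nnc(Sc3ncnc4ccccc34)s2)cc(OC)c1OC`: 61200 nM
- compound 3 `CCSc1ncnc2ccc(I)cc12`: 31100 nM

Compound 3 has the lowest of the three numbers in this assay. Its nearest neighbour is compound 2, whose number lies within the scatter of that of compound 3, so the two cannot be ranked against each other. Compound 1 sits beyond the scatter, with a higher number than compound 3.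

Compound 4 `CCCCSc1ncnc2ccc(I)cc12` is the next member, still unmeasured in this assay. Relative to compound 3 it carries ethyl in place of hydrogen on a saturated chain carbon, two bonds along the chain from a sulfur. Within the data shown here, no pair of measured compounds differing in exactly this way exists, so there is no measured step to lean on. The change is a small extension of a saturated chain without any new donor, acceptor or ring; the expectation is a small step in this assay, not beyond the scatter, and if anything toward a slightly lower number.

Compound 4 is thus estimated at 25000 nM, in the range 10000 nM to 60000 nM, which is expected to be a step of a 1.2-fold lower number from compound 3 to compound 4 (0.09 log units; within the scatter).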

Compound 4, half-maximal inhibitory concentration: 29000 nM
The estimate for compound 4 lay 1.2-fold (0.06 log units) below the measured number; the measured number falls inside the stated range.
By their numbers in this assay, from the lowest: compounds 4, 3, 2 and 1 (each within the scatter of the next, the first and the last beyond it).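

Among these compounds, the first one-place step, a 1.1-fold lower number from compound 3 to compound 4 (0.03 log units; within the scatter), is read in this assay and comes from ethyl in place of hydrogen on a saturated chain carbon, two bonds along the chain from a sulfur. Going from ethylsulfanyl to butylsulfanyl therefore does not separate the two compounds, so this added length on the saturated chain, with no ring, donor or acceptor entering, has no resolved effect on the antiproliferative read-out. The data offer no explanation for this result.

Still open, as far as these compounds go, is whether a longer chain such as hexyl, or a chain carrying an amine or a carboxylic acid, would produce a step beyond the scatter in this assay. The compounds shown also leave open whether the same extension would behave alike on a core without iodine.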